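A few compounds are considered here, and "the series" means these few. Any claim that something is new, unique, unknown or untested is made for them only; others in the source may bear on it.

Measured in a functional assay on U-373MG ATCC cells for cytotoxicity against U373 MG (Homo sapiens), read by colorimetric assay and MTT assay; a higher number here means a weaker inhibitor, a lower number a stronger inhibitor:
- compound 1 `COc1cc(OC)c2cc(-c3ccccc3)c(O)nc2c1`: 10000 nM
- compound 2 `COc1ccc(-c2cc3cccc(OC)c3nc2O)cc1`: 10000 nM
- compound 3 `COc1ccc(-c2cc3c(OC)cc(OC)cc3n(CC#N)c2=O)cc1`: 10000 nM

Compound 3 stands level with compound 1 and compound 2, within the scatter. Going by the values given here, no two measured compounds differ in only one place, so the series offers no measured step to draw on.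

Compound 4 `CCN(CC)C(=O)CCn1c(=O)c(-c2ccc(OC)cc2)cc2c(OC)cc(OC)cc21` has not yet been measured. It carries (diethylcarbamoyl)methyl in place of cyano on a saturated chain carbon bound to an aromatic nitrogen.

The step expected in this assay is no change at the digits printed from compound 3 to compound 4 (within the scatter), in neither direction beyond the scatter, resting on compound 3 at 10000 nM. For compound 4 the estimate is 10000 nM, with an expected range of 4000 nM to 15000 nM.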

Compound 4, half-maximal inhibitory concentration: 10000 nM
Beside the measured number, compound 4's estimate shows no gap at the digits printed; low and high end bracket the measured number.
By their numbers in this assay, from the lowest: compounds 1, 2, 3 and 4 (each within the scatter of the next).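

The first step read at this position comes in this assay: with (diethylcarbamoyl)methyl in place of cyano on a saturated chain carbon bound to an aromatic nitrogen, the step is no change at the digits printed from compound 3 to compound 4 (within the scatter). This position therefore takes the larger, amide-bearing chain with no step beyond the scatter in this assay. Nothing measured bears on why the number holds.

On these data alone, whether a chain ending in an amine or a carboxylic acid at this position would give a different number stays open. So does whether a shorter or longer chain carrying the same diethylamide would separate from compound 3.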